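Swapping the Propyl-Pyrazole Arm for a Chloropyridine

The source may hold more compounds than are shown below. What is called first, only, known or untested is meant among the compounds shown, and "the series" means these compounds.

Compound 2 `CCCn1cc(-c2cnc(NCc3ccc4c(c3)OCC4)c(C(=O)NCC3COc4ccccc4O3)c2)cn1` is the reference point here. In an assay on HEK293 cells for agonist activity at growth hormone secretagogue receptor type 1 (Rattus norvegicus), read by a luciferase reporter (a lower number here means a stronger inhibitor, a higher number a weaker inhibitor), compound 2 gives 140 nM, the lowest of the two numbers recorded. Its companion, compound 1 `CCCn1cc(-c2cnc(NCc3ccc4sccc4c3)c(C(=O)NCC3COc4ccccc4O3)c2)cn1`, gives 400 nM in this assay. Among the measured compounds shown here, the single measured step, a 2.9-fold lower number from compound 1 to compound 2 (0.46 log units; beyond the scatter), concerns a swap at the saturated chain carbon bound to a nitrogen on an aromatic ring, not the position now in question. Compound 3 `O=C(NCC1COc2ccccc2O1)c1cc(-c2ccnc(Cl)c2)cnc1NCc1ccc2c(c1)OCC2` carries 2-chloropyridin-4-yl in place of 1-propyl-1H-pyrazol-4-yl on an aromatic carbon. For the measured compounds named here, no measured step touches this position, so the only guide is that the shared core has so far tolerated one alteration elsewhere with a modest shift. The expectation is therefore a step of uncertain direction, a 1.6-fold higher number from compound 2 to compound 3 (0.20 log units; within the scatter), probably within or only just beyond the scatter. Compound 3 is estimated at 220 nM, with a likely range from 60 nM to 800 nM.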

Compound 3, half-maximal inhibitory concentration: 390 nM
Beside the measured number, compound 3's estimate is 1.8-fold (0.25 log units) below it; the range from low to high includes it.
By their numbers in this assay, from the lowest: compound 2; then compounds 3 and 1 (each within the scatter of the next).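

In this assay this position proves sensitive to the change: there is a 2.8-fold higher number from compound 2 to compound 3 (0.44 log units; beyond the scatter) when 2-chloropyridin-4-yl replaces 1-propyl-1H-pyrazol-4-yl, so the new group gives a modestly weaker inhibitor. The position, on an aromatic carbon of a six-membered aromatic ring with 1 nitrogen, therefore affects the number, yet it accepts a quite different ring with only this modest shift, and compound 3 still gives 390 nM. Nothing available here bears on why the number moved.

With only one replacement at this position, the separate roles of the ring, the chlorine and the propyl chain stay unresolved. A plain pyridin-4-yl without the chlorine, or a pyrazole carrying a methyl in place of the propyl, would help pull them apart.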